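The source may hold more compounds than are shown below. What is called first, only, known or untested is meant among the compounds shown, and "the series" means these compounds.

Compound 1 `CCCCC[Se]c1nc(NCc2ccccc2)c2ccccc2n1` gives 34500 nM in a functional assay on CCRF-CEM cells (Homo sapiens) for cytotoxicity, read by MTT assay, with a stated time of 72 h; on this read-out higher numbers stand for weaker inhibition of growth and lower numbers for stronger inhibition of growth.
Compound 2 `CSc1nc(NCc2ccccc2)c2ccccc2n1` gives 87900 nM in this assay.

Compound 2 stands highest of the two numbers; its nearest neighbour is compound 1, with a 2.5-fold higher number from compound 1 to compound 2 (0.41 log units; beyond the scatter). Compound 3 `CSc1nc(NCc2ccc([Se]C)cc2)c2ccccc2n1` differs from compound 2 by a group of 2 heavy atoms (1 carbon, 1 selenium; no ring) in place of a hydrogen atom, on an aromatic carbon, sitting on an aromatic carbon of a six-membered aromatic ring of carbon only, para to a large group. Going by the values given here, the single measured step, a 2.5-fold higher number from compound 1 to compound 2 (0.41 log units; beyond the scatter), changed the group on an aromatic carbon of the shared core rather than this ring, so it bears only loosely on the change. Compound 3 is therefore expected to show no step beyond the scatter, with an estimated 65000 nM, from 20000 nM to 200000 nM. The expected step is a 1.4-fold lower number from compound 2 to compound 3 (0.13 log units; within the scatter).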

Compound 3, concentration for 50% growth inhibition: 63300 nM
Estimate against measurement, compound 3: 1.0-fold (0.01 log units) above; the range from low to high includes it.
By their numbers in this assay, from the lowest: compounds 1, 3 and 2 (each within the scatter of the next, the first and the last beyond it).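

In this assay, the only change shown on the six-membered aromatic ring of carbon only, a group of 2 heavy atoms in place of a hydrogen atom, para to a large group, gives a 1.4-fold lower number from compound 2 to compound 3 (0.14 log units; within the scatter). At this position, then, the selenium-bearing group leaves the number within the scatter, whereas the earlier pair showed only a change on an aromatic carbon of the shared core. No measurement shown here accounts for this result. Going by these compounds, whether an amine, a carboxylic acid or a longer chain at this position would give a step beyond the scatter remains open.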